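A few compounds are considered here, and "the series" means these few. Any claim that something is new, unique, unknown or untested is made for them only; others in the source may bear on it.

Of the compounds shown here, three built around a shared core have been tested in a functional assay on A549 cells (Homo sapiens) for inhibition, read by MTT assay, with a stated time of 24 h; a lower number here means a stronger inhibitor of growth, a higher number a weaker inhibitor of growth. Compound 1 `COc1ccc2c(c1)c(-c1nc3ccccc3n1C(=O)c1ccccc1)cn2C` gives 16700 nM in this assay. Compound 2 `COc1ccc2c(c1)c(-c1nc3ccccc3n1C(=O)c1ccccc1OC)cn2C` gives 11900 nM and compound 3 `COc1ccc2c(c1)c(-c1nc3ccccc3n1C(=O)c1ccccc1Br)cn2C` gives 29500 nM in the same assay. The step of a 1.4-fold lower number from compound 1 to compound 2 (0.15 log units; within the scatter) and the step of a 1.8-fold higher number from compound 1 to compound 3 (0.25 log units; within the scatter) both stay within the scatter, whereas the step of a 2.5-fold higher number from compound 2 to compound 3 (0.39 log units; beyond the scatter) lies beyond it. Compound 4 `Cn1cc(-c2nc3ccccc3n2C(=O)c2ccccc2)c2cc(Br)ccc21` has not yet been measured in this assay.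

Compound 4 differs from compound 1 by bromo in place of methoxy on an aromatic carbon. The same kind of change separates compound 2 from compound 3, namely (bromo in place of methoxy on an aromatic carbon). The two changes are not the same, though: in compound 2 the exchanged group stands ortho to a large group, while in compound 1 it sits on a ring that is part of a fused or bridged system of two rings, meta to a fused ring and para to a fused ring. The cores of compound 1 and compound 2 themselves differ by hydrogen in place of methoxy on an aromatic carbon.

For the measured compounds named here, the only measured example of methoxy giving way to bromo is the step of a 2.5-fold higher number from compound 2 to compound 3 (0.39 log units; beyond the scatter), which raised the number modestly. Because the step of a 2.5-fold higher number from compound 2 to compound 3 (0.39 log units; beyond the scatter) raised the number modestly, a somewhat similar, though less certain, step from compound 1 to compound 4 is expected, estimated at a 1.8-fold higher number from compound 1 to compound 4 (0.25 log units; within the scatter) in size. Compound 4 is therefore estimated to give about 30000 nM in this assay, with a likely range from 12000 nM to 75000 nM.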

Compound 4, concentration for 50% growth inhibition: 23100 nM
Compound 4: the middle estimate sits 1.3-fold (0.11 log units) above what was measured; low and high end bracket the measured number.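

In this assay, moving from methoxy to bromo on the ring fused into the core gives a 1.4-fold higher number from compound 1 to compound 4 (0.14 log units; within the scatter), so on this core the exchange leaves compound 1 and compound 4 indistinguishable from one another. Set beside the same exchange on the benzoyl side of the molecule, the two steps cannot be told apart, so the data give no sign that the effect of this change depends on the core: the same change on two cores in this assay, a 2.5-fold higher number (0.39 log units; beyond the scatter) from compound 2 to compound 3 and a 1.4-fold higher number (0.14 log units; within the scatter) from compound 1 to compound 4, 1.8-fold (0.25 log units) apart, within the scatter of two such steps. This agreement is only a weak sign that the change carries over, since it rests on just two pairs, one of them within the scatter and each with the exchange at a different place, so it establishes no rule for the series and says nothing about why the numbers fall as they do.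

The compounds shown leave open how other groups at this place on the core of compound 1 would compare, for example an amine, a carboxylic acid or a longer chain. They also leave open what plain hydrogen there would give, and whether any group at this place could move the number beyond the scatter.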